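This account rests on a few compounds, and the source may have more. Where it says the series, first, only, none or still open, it means among the compounds named here.

The series shares one core. Compound 1 `COc1ccccc1/C=c1/[nH]c(=O)/c(=C\c2ccccc2OC)[nH]c1=O` gives "not determined" (no result reported) in a functional assay on MOLT-4 cells (Homo sapiens) for cytotoxicity, read by CCK-8 assay, with a stated time of 72 h (a lower number here means a stronger inhibitor, a higher number a weaker inhibitor), that is, no result was reported for it. Compound 2 `COc1ccccc1/C=c1\c(=O)[nH]/c(=C/c2cccc(Cl)c2Cl)c(=O)n1C` likewise gives "not determined" (no result reported) in this assay, again no reported result. Going by the values given here, compound 3 `C=CCn1c(=O)/c(=C\c2cccc(F)c2)[nH]c(=O)/c1=C\c1ccccc1OC` gives 6500 nM in this assay, the only number among the three, so it stands alone and cannot be ranked against the others. Compound 4 `C=CCn1c(=O)/c(=C\c2ccc(F)c(Br)c2)[nH]c(=O)/c1=C\c1ccccc1OC` has not yet been measured. It differs from compound 3 by 3-bromo-4-fluorophenyl in place of 3-fluorophenyl on a double-bonded chain carbon bound to an aromatic carbon. Among the compounds with values here, no pair of measured compounds differing in one place is available, so the size of this step is uncertain; the author expects a small shift, likely within the scatter or at most a modest move toward stronger inhibition, and estimates the step at a 1.4-fold lower number from compound 3 to compound 4 (0.16 log units; within the scatter). Compound 4 is therefore expected to give 4500 nM in this assay, with a range from 1500 nM to 14000 nM.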

Compound 4, half-maximal inhibitory concentration: "not active" (no number reported)
Nothing numeric was reported for compound 4, so the estimate cannot be set against anything.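

No step can be read from compound 3 to compound 4 in this assay, as compound 4 carries no number. No measurement at hand bears on this result. The compounds shown leave open how 3-bromo-4-fluorophenyl and 3-fluorophenyl compare numerically.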